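Azepane for Ethylpiperazine on the Shared Core

This account rests on a few compounds, and the source may have more. Where it says the series, first, only, none or still open, it means among the compounds named here.

The series shares a fused core carrying a sulfonyl group and an amine ring. Compound 1 `CC1CCN(c2c(S(=O)(=O)c3cc(F)cc(F)c3)cnc3cc(Cl)ccc23)CC1` carries a 4-methylpiperidine and a difluorophenylsulfonyl group; in an assay on isolated protein for displacement of a labelled ligand from metabotropic glutamate receptor 5 (Homo sapiens), with a stated time of 60 min (a lower number here means a stronger inhibitor, a higher number a weaker inhibitor), compound 1 gives 195 nM. Compound 2 `O=S(=O)(c1cccc(Cl)c1)c1cnc2cc(Cl)ccc2c1N1CCC(CO)CC1` carries a 4-(hydroxymethyl)piperidine and a chlorophenylsulfonyl group; in this assay compound 2 gives 30.9 nM. The two differ at more than one place, so their values are only read side by side. Compound 3 `CCN1CCN(c2c(S(=O)(=O)c3ccccc3)cnc3ccccc23)CC1` carries a 4-ethylpiperazine and a phenylsulfonyl group on the core without chlorine. Compound 3 has no number: in this assay compound 3 gives "not determined" (no result reported), so it stands nowhere on the measured scale.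

Compound 4 `O=S(=O)(c1ccccc1)c1cnc2ccccc2c1N1CCCCCC1` arises from compound 3 through (azepan-1-yl in place of 4-ethylpiperazin-1-yl on an aromatic carbon). For the measured compounds named here, with no number for compound 3 and no step between compounds that differ in one place, no size or direction for this step can be read from the data, and only the region set by compound 1 and compound 2 offers a reference.

Compound 4 is expected to give about 150 nM in this assay, with a plausible range from 25 nM to 900 nM.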

Compound 4, inhibition constant: 310 nM
The estimate for compound 4 lay 2.1-fold (0.32 log units) below the measured number; measured number inside the range.
By their numbers in this assay, from the lowest: compound 2; then compounds 1 and 4 (each within the scatter of the next).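

For the compounds shown here, compound 3 has no number in this assay so no step from compound 3 to compound 4 can be read, and compound 4 differs from compound 1 and compound 2 at more than one place. The compounds shown leave open how azepan-1-yl compares with 4-ethylpiperazin-1-yl on the shared core. No measured evidence bears on this result.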